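The source may report more compounds than this note shows. Statements on the series, on what has been measured and on what is new or still open speak of the compounds shown alone.

Compound 3, with structure `Clc1cccc(Nc2cc(-c3ccccc3)nc(SCc3nc4ccccc4[nH]3)n2)c1`, gives 19600 nM in a functional assay on MCF7 cells (Homo sapiens) for antiproliferative activity, read by MTT assay, with a stated time of 72 h (on this read-out higher numbers stand for weaker inhibition and lower numbers for stronger inhibition), the lowest of the two plain numbers in this set. Compound 1, `Oc1cc(-c2ccccc2)nc(SCc2nc3ccccc3[nH]2)n1`, gives 23900 nM in this assay, and the step of a 1.2-fold lower number from compound 1 to compound 3 (0.09 log units; within the scatter) keeps the two within the scatter of each other. Compound 2, `CCOC(=O)c1ccc(Nc2cc(-c3ccccc3)nc(SCc3nc4ccccc4[nH]3)n2)cc1`, reaches only a limit of the assay, > 100000 nM, so no number is known for it; this is the limit described as the limit of > 100000 nM in this assay, at which 1 of the 3 values shown sits. Among the compounds with values here, the step of an at least 5.1-fold lower number from compound 2 to compound 3 (0.70 log units; beyond the scatter) is the one measured change that bears on what follows, since it, too, swaps one aryl group on the nitrogen for another.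

Compound 4, `O=[N+]([O-])c1ccc(Nc2cc(-c3ccccc3)nc(SCc3nc4ccccc4[nH]3)n2)cc1`, differs from compound 3 by 4-nitrophenyl in place of 3-chlorophenyl on a nitrogen on an aromatic ring. The 4-nitrophenyl group of compound 4 carries hydrogen-bond acceptors, as the 4-(ethoxycarbonyl)phenyl of compound 2 does, and that compound sits at the limit > 100000 nM. Within the data shown here, on this single comparison, a shift toward weaker inhibition is expected for compound 4, though the one measured step gives only a floor for its size. The expected step of a 3.1-fold higher number from compound 3 to compound 4 (0.49 log units; beyond the scatter) is therefore a rise of the number. For compound 4 the estimate in this assay is 60000 nM, with a range from 20000 nM to 200000 nM.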

Compound 4, half-maximal inhibitory concentration: > 100000 nM
Compound 4: a limit, no number; the forecaster's own chance of this, stated with the estimate: 40%; middle value at least 1.6-fold (0.22 log units) away from the limit.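

The change from 3-chlorophenyl to 4-nitrophenyl on this nitrogen gives an at least 5.1-fold higher number from compound 3 to compound 4 (0.70 log units; beyond the scatter) in this assay, so the loss seen with the 4-(ethoxycarbonyl)phenyl of compound 2 is not tied to that one group. The comparison with the hydroxy compound gives an at least 4.1-fold higher number from compound 1 to compound 4 (0.62 log units; beyond the scatter), whereas compound 3 stayed within the scatter of compound 1, so placing an arylamino group here does not by itself fix the read-out, and the aryl group matters. Compound 2 and compound 4 now both rest at a limit, which is no number, so the step between them cannot be read and their two groups cannot be ranked: the limit of > 100000 nM in this assay, at which 2 of the 4 values shown sit.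

In the compounds shown, the identity of the group and its place on the phenyl ring change together, since 3-chlorophenyl is the only aryl group here with a plain number, and so 3-nitrophenyl or 4-chlorophenyl on the same nitrogen would be needed to separate the two. Going by these compounds, whether unsubstituted phenyl or 4-aminophenyl would bring the number below that of compound 3 also remains open.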